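Dinitrophenyl Swap on a Scaffold Without Measurable Activity

This account rests on a few compounds, and the source may have more. Where it says the series, first, only, none or still open, it means among the compounds named here.

Compound 1 `N#CC1=C(N)Oc2c(N)cc3nc4ccccc4nc3c2C12C(=O)N(Cc1cnnn1-c1ccc(Cl)cc1)c1ccccc12` and compound 2 `N#CC1=C(N)Oc2c(N)cc3nc4ccccc4nc3c2C12C(=O)N(Cc1cnnn1-c1c(F)cccc1F)c1ccccc12` share the same spiro-fused core and differ only in the aryl group attached to an aromatic nitrogen. In an ADME assay on HUVEC cells (Homo sapiens) for antiproliferative activity, read by MTT assay, with a stated time of 48 h (a lower number here means a stronger inhibitor, a higher number a weaker inhibitor), compound 1 gives > 50000 nM, which is a limit of the assay rather than a number. In this assay compound 2 gives > 50000 nM, again only a limit. The change from compound 1 to compound 2 is therefore a step that the two limits leave unreadable from compound 1 to compound 2. Every value recorded so far is the limit of > 50000 nM in this assay, at which 2 of the 2 values shown sit.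

Compound 3 `N#CC1=C(N)Oc2c(N)cc3nc4ccccc4nc3c2C12C(=O)N(Cc1cnnn1-c1ccc([N+](=O)[O-])cc1[N+](=O)[O-])c1ccccc12` carries 2,4-dinitrophenyl in place of 2,6-difluorophenyl on an aromatic nitrogen. Among the compounds with values here, no measured step gives a readable direction for this kind of change, so nothing beyond the scatter can be predicted from the data in hand. The expected step from compound 2 to compound 3 is a step that the limit leaves unreadable from compound 2 to compound 3. Compound 3 is estimated at 60000 nM, probably again reported only as a limit, with a range from 20000 nM to 200000 nM.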

Compound 3, half-maximal inhibitory concentration: > 50000 nM
Compound 3 was reported as a limit; the forecaster's own chance of this, stated with the estimate: 85%; the middle value is on the limit's open side.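

In this assay compound 3 gives > 50000 nM as a limit, not a number, so the steps linking compound 1, compound 2 and compound 3 cannot be read. Still open is whether any aryl group on the shared core gives a readable value: the limit of > 50000 nM in this assay, at which 3 of the 3 values shown sit.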